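The source may report more compounds than this note shows. Statements on the series, on what has been measured and on what is new or still open speak of the compounds shown alone.

Values in a physicochemical assay for lipophilicity; a higher number here means a more lipophilic compound, a lower number a more polar compound:

- Compound 1 `C[C@H]1CC[C@@H]2[C@@H](OC(=O)[C@]23CC(c2ccc(C#N)cc2)N(c2ccccc2)O3)[C@]2(C)C(=O)C=C[C@@]12O`: 2.94
- Compound 2 `Cc1ccccc1C1C[C@@]2(ON1c1ccccc1)C(=O)O[C@@H]1[C@H]2CC[C@H](C)[C@]2(O)C=CC(=O)[C@@]12C`: 3.64
- Compound 3 `C[C@H]1CC[C@@H]2[C@@H](OC(=O)[C@]23CC(c2cccc(F)c2)N(c2ccccc2)O3)[C@]2(C)C(=O)C=C[C@@]12O`: 3.35

Among these three, compound 3 has a close neighbour on one side only. The step of a number 0.29 log units lower from compound 2 to compound 3 (within the scatter) does not separate the two values, whereas the step of a number 0.41 log units higher from compound 1 to compound 3 (beyond the scatter) is a real, modest difference.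

The next compound is compound 4 `COc1cccc(C2C[C@@]3(ON2c2ccccc2)C(=O)O[C@@H]2[C@H]3CC[C@H](C)[C@]3(O)C=CC(=O)[C@@]23C)c1`, which carries methoxy in place of fluoro on an aromatic carbon, meta to a large group: methoxy in place of fluoro on an aromatic carbon. Within the data shown here, no measured pair makes this exchange, so the evidence is indirect. The nearest guides are the swaps of one substituted phenyl for another on a saturated ring carbon. The largest of them is a number 0.70 log units higher from compound 1 to compound 2 (beyond the scatter), which is still modest, and both steps that leave 4-cyanophenyl behind are of modest size.

Among the measured compounds shown here, the expectation of a small change for compound 4 leans on a number 0.29 log units lower from compound 2 to compound 3 (within the scatter), the one swap between phenyl groups that both lack 4-cyanophenyl. No step beyond the scatter is expected in this assay, and the direction is uncertain. The estimated change is a number 0.10 log units lower from compound 3 to compound 4 (within the scatter). For compound 4 the expected value is 3.25, with an estimated range from 2.9 to 3.6.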

Compound 4, partition coefficient: 3.25
The estimate for compound 4 equals the measured number at the digits printed, and the stated range covers the measured number.
By their numbers in this assay, from the lowest: compound 1; then compounds 4, 3 and 2 (each within the scatter of the next, the first and the last beyond it).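

At this aromatic carbon, meta to a large group, the exchange of fluoro for methoxy gives a number 0.10 log units lower from compound 3 to compound 4 (within the scatter), so this assay does not tell the two groups apart, even though methoxy is the larger by heavy atoms and is the one of the two counted with a hydrogen-bond acceptor. The comparison with the other two compounds adds a sharper picture of the series: a number 0.39 log units lower from compound 2 to compound 4 (beyond the scatter) is a real though modest difference, unlike the step from compound 2 to compound 3, and a number 0.31 log units higher from compound 1 to compound 4 (beyond the scatter) leaves compound 1 beyond the scatter of each of the other three compounds, which makes the swap away from 4-cyanophenyl the third in a row to give a modest step. No measurement shown offers an explanation for any of these numbers.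

Fluoro and methoxy are seen together at this one place only, so it remains open whether they would stay as close at another carbon of the same phenyl ring. It also remains open how far the number would move with an amine or a carboxylic acid at this aromatic carbon, since every group shown on this phenyl ring is uncharged.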